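Swapping a fluorophenyl for a chlorofluorophenyl on the shared core

The source may hold more compounds than are shown below. What is called first, only, known or untested is meant among the compounds shown, and "the series" means these compounds.

Compound 1, `COc1nc(C2CCOCC2)ccc1[C@@H](c1ccccc1)[C@@](O)(CCN(C)C)c1cccc2ccccc12`, gives 22.5 ug/mL in a toxicity assay on HeLa cells (Homo sapiens) for cytotoxicity; a lower number here means that less compound is tolerated, a higher number that more compound is tolerated.
Compound 2, `COc1nc(-c2cccc(Cl)c2)ccc1[C@@H](c1ccccc1)[C@@](O)(CCN(C)C)c1cccc2ccccc12`, gives "nd" (no result reported) in this assay.
Compound 3, `COc1nc(-c2ccc(F)cc2)ccc1[C@@H](c1ccccc1)[C@@](O)(CCN(C)C)c1cccc2ccccc12`, gives > 64 ug/mL in this assay.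

The value of compound 3 is not a number but (the limit of > 64 ug/mL in this assay, at which 1 of the 3 values shown sits). With compound 2 lacking a result, compound 3 stands as the better-tolerated of the two numbered entries, since an at least 2.8-fold higher number from compound 1 to compound 3 (0.45 log units; beyond the scatter) lies beyond the scatter.

Compound 4, `COc1nc(-c2ccc(Cl)c(F)c2)ccc1[C@@H](c1ccccc1)[C@@](O)(CCN(C)C)c1cccc2ccccc12`, differs from compound 3 by 4-chloro-3-fluorophenyl in place of 4-fluorophenyl on an aromatic carbon. Within the data shown here, no measured step exchanges one halogenated phenyl for another, so the only available step is a loose guide. The expectation is a step of no size beyond the scatter, a number no higher from compound 3 to compound 4 (the limit leaves the size open). Compound 4 is therefore expected at 64 ug/mL, within 32 ug/mL to 128 ug/mL, with a good chance that this assay again reports only a limit.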

Compound 4, half-maximal cytotoxic concentration: > 64 ug/mL
Compound 4: a limit, no number (the forecaster's own chance of this, stated with the estimate: 60%); the middle value sits exactly at the limit.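

At this position, next to the ring nitrogen, a second halogenated phenyl also beats oxan-4-yl, with an at least 2.8-fold higher number from compound 1 to compound 4 (0.45 log units; beyond the scatter), so this gain no longer rests on 4-fluorophenyl alone. In this assay compound 4 gives > 64 ug/mL, which is a limit and not a number. The step between compound 3 and compound 4 cannot be read, since both sit at the same limit: the limit of > 64 ug/mL in this assay, at which 2 of the 4 values shown sit.

Going by these compounds, how far either compound lies past that limit stays open, and with it any effect of the added chlorine. Also open, on these data alone, is how an amine or a carboxylic acid on the phenyl would fare here.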